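Replacing a Nitrooxyphenyl Group with a Dichlorophenyl Group

The source may report more compounds than this note shows. Statements on the series, on what has been measured and on what is new or still open speak of the compounds shown alone.

Three relatives of one shared core have been examined, each differing only in the aryl group attached to a carbon with a double bond to nitrogen. Compound 2 `CN(C)CCn1cnnc1-c1cc(Oc2ccc(NC(=O)N/N=C/c3ccc(Cl)cc3)cc2F)ccn1` carries a 4-chlorophenyl there, compound 3 `CN(C)CCn1cnnc1-c1cc(Oc2ccc(NC(=O)N/N=C/c3ccccc3O[N+](=O)[O-])cc2F)ccn1` a 2-(nitrooxy)phenyl, and compound 1 `CN(C)CCn1cnnc1-c1cc(Oc2ccc(NC(=O)N/N=C/c3cccc(O)c3)cc2F)ccn1` a third variant. Their cytotoxicity was assessed in an ADME assay on WI-38 cells (Homo sapiens) for cytotoxicity, read by MTT assay, with a stated time of 72 h; on this read-out higher numbers stand for weaker inhibition and lower numbers for stronger inhibition. In this assay compound 2 gives 1870 nM, compound 3 gives 6860 nM, and for compound 1 the record reads "not determined" (no result reported). Of the two numbers, compound 3 stands highest; its nearest neighbour is compound 2, and the step of a 3.7-fold higher number from compound 2 to compound 3 (0.56 log units; beyond the scatter) lies beyond the usual scatter, so compound 3 inhibits these cells less strongly.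

Compound 4 `CN(C)CCn1cnnc1-c1cc(Oc2ccc(NC(=O)N/N=C/c3c(Cl)cccc3Cl)cc2F)ccn1` is the next variant. Its change from compound 3 is 2,6-dichlorophenyl in place of 2-(nitrooxy)phenyl on a carbon with a double bond to nitrogen. Among the compounds with values here, the only measured step that bears on this exchange is the one from compound 2 to compound 3, in which the arrival of the 2-(nitrooxy)phenyl raised the number. Here that group leaves and chlorine returns, now as two atoms instead of one; no measured pair shows what a second chlorine does. A modest lowering of the number is expected, a step of about a 2.7-fold lower number from compound 3 to compound 4 (0.44 log units; beyond the scatter). Compound 4 is therefore expected to give 2500 nM, within a range from 900 nM to 7000 nM.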

Compound 4, half-maximal inhibitory concentration: 3320 nM
The estimate for compound 4 lay 1.3-fold (0.12 log units) below the measured number, within the range that was stated.
By their numbers in this assay, from the lowest: compounds 2 and 4 (each within the scatter of the next); then compound 3.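

Exchanging the 2-(nitrooxy)phenyl for a 2,6-dichlorophenyl on the carbon with a double bond to nitrogen gives a 2.1-fold lower number from compound 3 to compound 4 (0.32 log units; beyond the scatter) in this assay, so a second aryl group carrying chlorine now sits on the lower side of compound 3, where before there was only one. The two chlorine-bearing compounds cannot be told apart here: a 1.8-fold higher number from compound 2 to compound 4 (0.25 log units; within the scatter) is a gap no larger than repeated measurements would produce, so moving from 4-chlorophenyl to 2,6-dichlorophenyl makes no readable difference to this cytotoxicity read-out. No supporting measurement is available to say what lies behind either step.

With only these compounds, the effect of the number of chlorine atoms cannot be separated from the effect of where they stand on the ring, since the 4-chlorophenyl and the 2,6-dichlorophenyl differ in both. From the compounds shown here alone, it also remains open how the number would respond to a plain phenyl ring, or to a ring carrying an amine or a carboxylic acid, at this same position.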